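Replacing Cyclopropyl with tert-Butyl: An Estimate for Compound 3

A few compounds are considered here, and "the series" means these few. Any claim that something is new, unique, unknown or untested is made for them only; others in the source may bear on it.

Compound 1 `Cc1c(C(=O)Nc2ccc(Oc3ncnc4[nH]cc(-c5ccccc5)c34)c(F)c2)c(=O)c2cc(F)ccc2n1C` gives > 10000 nM in an assay on isolated protein for inhibition of tyrosine-protein kinase receptor UFO (Homo sapiens), read by FRET and Z'-LYTE, with a stated time of 1.5 h; a higher number here means a weaker inhibitor, a lower number a stronger inhibitor. Compound 2 `Cc1c(C(=O)Nc2ccc(Oc3ncnc4[nH]cc(-c5ccccc5)c34)c(F)c2)c(=O)c2cc(C3CC3)ccc2n1C` gives 230 nM in this assay.

The value for compound 1 is a limit of the assay, not a number. Compound 2 holds the only number shown; the other entry is the limit of > 10000 nM in this assay, at which 1 of the 2 values shown sits. Compound 3 `Cc1c(C(=O)Nc2ccc(Oc3ncnc4[nH]cc(-c5ccccc5)c34)c(F)c2)c(=O)c2cc(C(C)(C)C)ccc2n1C` differs from compound 2 by tert-butyl in place of cyclopropyl on an aromatic carbon. Within the data shown here, the one measured step, an at least 43-fold lower number from compound 1 to compound 2 (1.63 log units; beyond the scatter), touches the same place: it shows that exchanging fluoro for a small alkyl group there made a large difference. Among the measured compounds shown here, the move to compound 3 keeps an alkyl group at that place, so no step beyond the scatter is expected, with a wide range to allow for the single measured number. Compound 3 is therefore estimated at 300 nM, between 60 nM and 1500 nM, which means an expected step of a 1.3-fold higher number from compound 2 to compound 3 (0.12 log units; within the scatter) in this assay.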

Compound 3, half-maximal inhibitory concentration: 42 nM
For compound 3 the middle estimate is 7.1-fold (0.85 log units) above the measured one; measured number below the stated range.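

In this assay, the exchange at this aromatic carbon gives a 5.5-fold lower number from compound 2 to compound 3 (0.74 log units; beyond the scatter), so the earlier finding that an alkyl group there beats fluoro does not mean that all alkyl groups behave alike: the choice of alkyl group itself matters at this place. Measured against fluoro, tert-butyl gives an at least 230-fold lower number from compound 1 to compound 3 (2.37 log units; beyond the scatter), a larger step than cyclopropyl gave. The size of both steps from compound 1 remains open-ended, as the value of compound 1 is a limit of the assay and not a number: the limit of > 10000 nM in this assay, at which 1 of the 3 values shown sits.

The compounds shown cannot separate the extra carbon of tert-butyl from the loss of the three-membered ring, a question that isopropyl or 1-methylcyclopropyl at this place would address. They also say nothing about how a longer chain, an ether or an amine would fare here.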